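Compound 4: Fluorophenyl in Place of Dichlorophenyl

The compounds below may be only part of what the source reports. "The series", "measured", "known", "first", "only" and "open" are said of these compounds alone.

Of the compounds shown here, three have been measured in a functional assay on SF-268 cells (Homo sapiens) for inhibition, tested at 10 uM; on this read-out lower numbers stand for less inhibition and higher numbers for more inhibition at the one concentration tested (going by the name of the read-out). Compound 1 `COc1ccc(Nc2ncccc2C(=O)NNS(=O)(=O)c2ccc(C)cc2)cc1` gives 106% in this assay. Compound 3 `O=C(NNS(=O)(=O)c1ccc(Cl)cc1Cl)c1cccnc1Nc1ccc(Cl)cc1` gives 34% in this assay. Compound 2 `O=C(NNS(=O)(=O)c1ccc(F)cc1)c1cccnc1Nc1ccc(Cl)cc1Cl` gives 0% in this assay, the lowest of the three numbers; its nearest neighbour is compound 3, whose number is higher by a margin beyond the scatter, and compound 1 lies furthest above it, also beyond the scatter. Going by the values given here, none of these three differs from another in only one place, so no single step between measured compounds can be read off.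

Compound 4 `O=C(NNS(=O)(=O)c1ccc(F)cc1)c1cccnc1Nc1ccc(F)cc1` has not yet been measured. It differs from compound 2 in one place: 4-fluorophenyl in place of 2,4-dichlorophenyl on a nitrogen on an aromatic ring. Among the compounds with values here, both compound 1 and compound 3 carry a phenyl with a single substituent at that nitrogen and show more inhibition than compound 2, so an increase is expected for compound 4, though with wide uncertainty, because its value in this assay given for compound 2 is 0% and no pair isolates this change. The step from compound 2 to compound 4 is expected to be a number 30 percentage points higher from compound 2 to compound 4 (beyond the scatter). Compound 4 is estimated at 30%, within a range from 0% to 75%.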

Compound 4, a percentage reported as inhibition, at one concentration (the size of the read-out at that concentration, not a potency): 123%
For compound 4 the middle estimate is 93 percentage points below the measured one, outside the stated range (above it).
By their numbers in this assay, from the lowest: compound 2; then compound 3; then compound 1; then compound 4.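

In this assay, the exchange of 2,4-dichlorophenyl for 4-fluorophenyl on a nitrogen on an aromatic ring gives a number 123 percentage points higher from compound 2 to compound 4 (beyond the scatter), a large change. Going by these compounds alone, this is the first single change that can be read, and it shows that the read-out is highly sensitive to the group at this nitrogen while the rest of the molecule stays fixed. Nothing shown here accounts for the size of this step.

The compounds shown leave open whether the step comes from losing the chlorine atoms, from gaining the fluorine, or from both together. They also leave open how a cyclohexyl group, or a phenyl carrying a carboxylic acid, would behave on this nitrogen.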